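Cytotoxicity limits and a phenyl swap in the series

The source may report more compounds than this note shows. Statements on the series, on what has been measured and on what is new or still open speak of the compounds shown alone.

compound 1 `C=C[C@@](C)(/C=C/c1ccc(Nc2ccc(OC)cc2)cc1)CCC=C(C)C`: > 36600 nM
compound 2 `C=C[C@@](C)(/C=C/c1ccc(Nc2ccc(OC(F)(F)F)cc2)cc1)CCC=C(C)C`: > 36600 nM
compound 3 `C=C[C@@](C)(/C=C/c1ccc(Nc2c(F)cc(F)cc2F)cc1)CCC=C(C)C`: > 36600 nM

In an ADME assay on BJ cells (Homo sapiens) for cytotoxicity, with a stated time of 72 h (a lower number here means that less compound is needed, a higher number that more compound is needed for the effect), compound 1 gives > 36600 nM, which is a limit and not a number. Compound 1 has no measured value to serve as a reference, and the other two compounds offer none either: the series stands at the limit of > 36600 nM in this assay, at which 3 of the 3 values shown sit.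

The next compound is compound 4 `C=C[C@@](C)(/C=C/c1ccc(-c2ccccc2)cc1)CCC=C(C)C`. The change is phenyl in place of (4-methoxyphenyl)amino on an aromatic carbon. The amino group that links the two aromatic rings in compound 1 is therefore gone from compound 4.

Going by the values given here, two measured steps bear on this change: a step that the two limits leave unreadable from compound 1 to compound 2 and a step that the two limits leave unreadable from compound 1 to compound 3. Neither has a readable size. In both, the amino group stays in place, so neither is a direct precedent for its removal. These steps give no direction, and no step beyond the usual scatter can be argued from them in this assay. The assay may well report only a limit again for compound 4.

For compound 4 the expected value is 40000 nM, with an estimated range of 15000 nM to 80000 nM.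

The estimate corresponds to an expected step that the limit leaves unreadable from compound 1 to compound 4.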

Compound 4, half-maximal effective concentration: > 36600 nM
Compound 4: no number, only a limit; the forecaster's own chance of this, stated with the estimate: 75%; the middle value does not contradict the limit.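

In this assay compound 4 gives > 36600 nM, which is a limit and not a number. Compound 1 also stands only at a limit, so no step can be read between compound 1 and compound 4. The series remains at one level: the limit of > 36600 nM in this assay, at which 4 of the 4 values shown sit.

The compounds shown leave open where any of them would give a measured value in this assay, and whether the amino group has any bearing on it.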